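Replacing a Selenium Chain by an Amino Group

The source may hold more compounds than are shown below. What is called first, only, known or untested is meant among the compounds shown, and "the series" means these compounds.

Measured so far:
- Compound 1, `CCCCC[Se]c1nc([Se]CCCCC)c2cccnc2n1`: in a functional assay on CCRF-CEM cells (Homo sapiens) for cytotoxicity, read by MTT assay, with a stated time of 72 h (a lower number here means a stronger inhibitor of growth, a higher number a weaker inhibitor of growth), compound 1 gives > 100000 nM, which is a limit of the assay and not a number.
- Compound 2, `CCCCC[Se]c1nc(NCc2ccccc2)c2ccccc2n1`: in this assay compound 2 gives 34500 nM.

Compound 1 carries two identical selenium-bearing chains on its core. From the compounds shown here alone, its result is only a limit, the line at which one of the two values shown sits (the limit of > 100000 nM in this assay, at which 1 of the 2 values shown sits), so no growth inhibition was seen up to that point and its true position is unknown. Compound 2 differs from compound 1 in more than one place, so no single step joins the two and its number is shown only for comparison.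

Compound 3, `CCCCC[Se]c1nc(N)c2cccnc2n1`, has not been measured. It differs from compound 1 by one nitrogen atom in place of a group of 6 heavy atoms (5 carbon, 1 selenium; no ring), on an aromatic carbon. Within the data shown here, no measured step tells how this change acts, so the direction rests only on compound 1 standing at a limit. The step from compound 1 to compound 3 is expected to be small, as an at least 1.4-fold lower number from compound 1 to compound 3 (0.15 log units; that floor lies within the scatter). Compound 3 is therefore estimated at 70000 nM, somewhere between 15000 nM and 300000 nM.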

Compound 3, concentration for 50% growth inhibition: 12900 nM
Compound 3: the middle estimate sits 5.4-fold (0.73 log units) above what was measured, and the stated range ends above it.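

In this assay, putting an amino group in place of the group of 6 heavy atoms on this aromatic carbon gives an at least 7.7-fold lower number from compound 1 to compound 3 (0.88 log units; beyond the scatter), so this position of the shared core is one where a single change can shift growth inhibition beyond the scatter. The step also shows that the second selenium-bearing chain is not needed for a measurable reading, since compound 3 keeps only one such chain and still gives a number rather than a limit. The true size of the step stays unknown, since one of its two ends is not a number: the limit of > 100000 nM in this assay, at which 1 of the 3 values shown sits.

This single step removes a selenium-bearing chain and adds an amino group at once, so it cannot tell whether the loss of the chain or the arrival of the amino group matters more, and a small group such as a methyl or a methylamino at the same place would be needed to pull the two apart. Also open, from the compounds shown here alone, is what the remaining selenium-bearing chain contributes, which a shorter chain such as an ethyl on selenium, or a sulfur atom in place of selenium, could begin to show.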